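A few compounds are considered here, and "the series" means these few. Any claim that something is new, unique, unknown or untested is made for them only; others in the source may bear on it.

Measured so far in a functional assay on the whole organism for inhibition, with Mus musculus as the target; a lower number here means that less compound is needed, a higher number that more compound is needed for the effect
compound 1 `CN1Cc2c(N)cccc2C(c2ccc(F)cc2)C1` gives about 3.6 mg/kg
compound 2 `CCCNC(=O)Nc1cccc2c1CN(C)CC2c1ccccc1` gives > 80 mg/kg as a limit

Compound 2 stands at the limit of > 80 mg/kg in this assay, at which 1 of the 2 values shown sits, and that entry is a limit, not a number. Compound 3 `CC(C)NCC(=O)Nc1cccc2c1CN(C)CC2c1ccccc1` keeps the core of compound 2 and differs in one place, (isopropylamino)methyl in place of propylamino on a carbonyl carbon here, with (isopropylamino)methyl in place of propylamino on a carbonyl carbon. Among the measured compounds shown here, no step between measured compounds is available to size this change. Compound 1 at about 3.6 mg/kg shows that the shared core can give a measurable dose, so a moderate move toward a lower dose is expected. Compound 3 may still end at a limit. The expected change is an at least 2.6-fold lower number from compound 2 to compound 3 (0.42 log units; beyond the scatter) as an estimate set against a limit. For compound 3 the estimated dose is 30 mg/kg with an expected range of 6 mg/kg to 100 mg/kg for now.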

Compound 3, dose for half-maximal effect: 14 mg/kg
Compound 3: middle estimate off by 2.1-fold (0.33 log units), on the high side; the range from low to high includes it.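

In this assay the change from propylamino to (isopropylamino)methyl on a carbonyl carbon gives a readable dose on the core of compound 2, so this position clearly bears on the result. The change amounts to an at least 5.7-fold lower number from compound 2 to compound 3 (0.75 log units; beyond the scatter) in this series. That size is only a bound, since the value for compound 2 is a limit and not a number: the limit of > 80 mg/kg in this assay, at which 1 of the 3 values shown sits.

This single change alters both the chain and the place of its amine, so the compounds shown do not separate the isopropyl branch from the methyl link that carries the amine. Also open, on these data alone, is how a straight propyl chain on that methyl link, or a tertiary amine such as dimethylamino, would read in this assay on this core.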